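The source may report more compounds than this note shows. Statements on the series, on what has been measured and on what is new or still open speak of the compounds shown alone.

Compound 1 `Nc1cc(N)c2nc(-c3ccccc3)c(NCc3ccc(F)cc3)nc2c1` gives in a functional assay on PC-3 cells (Homo sapiens) for inhibition, read by sulforhodamine B assay, with a stated time of 48 h; on this read-out higher numbers stand for lower toxicity in this test and lower numbers for higher toxicity in this test < 100000 nM, which is a limit of the assay.
Compound 2 `Nc1cc(N)c2nc(-c3ccccc3)c(Sc3ccc(Cl)c(Cl)c3)nc2c1` gives in this assay < 100000 nM, again only a limit.

Compound 2 therefore stands at a limit in this assay, and both values shown sit there (the limit of < 100000 nM in this assay, at which 2 of the 2 values shown sit). Among the measured compounds shown here, the single measured step, a step that the two limits leave unreadable from compound 1 to compound 2, cannot be read. Compound 3 `Nc1cc(N)c2nc(-c3ccccc3)c(Oc3ccc(F)cc3)nc2c1` differs from compound 2 by 4-fluorophenoxy in place of (3,4-dichlorophenyl)sulfanyl on an aromatic carbon. For the measured compounds named here, no measured step bears on this change, so no direction is known beyond the scatter. The step expected from compound 2 to compound 3 is a step that the limit leaves unreadable from compound 2 to compound 3. Compound 3 is expected to give 30000 nM in this assay, between 5000 nM and 100000 nM.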

Compound 3, concentration lethal to 50% of the cells: 83200 nM
For compound 3 the middle estimate is 2.8-fold (0.44 log units) below the measured one; low and high end bracket the measured number.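

Among the compounds shown here, no step from compound 1 or compound 2 to compound 3 can be read, because compound 1 and compound 2 give only limits: the limit of < 100000 nM in this assay, at which 2 of the 3 values shown sit. The compounds shown leave open how the three groups at this place compare in this assay.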